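Methoxy for Methyl on the Fused Ring of Compound 2

The source may report more compounds than this note shows. Statements on the series, on what has been measured and on what is new or still open speak of the compounds shown alone.

Compound 1 `CS(=O)(=O)c1ccc(Nc2nccc(Nc3nc4ccccc4s3)n2)cc1` carries the shared core and gives 10600 nM in a functional assay on MCF7 cells (Homo sapiens) for antiproliferative activity, read by MTT assay, with a stated time of 48 h; a higher number here means a weaker inhibitor, a lower number a stronger inhibitor. Compound 2 `Cc1ccc2nc(Nc3ccnc(Nc4ccc(S(C)(=O)=O)cc4)n3)sc2c1` differs from it by a methyl group on an aromatic carbon. In this assay compound 2 reaches only a limit of the assay, > 50000 nM. The step of an at least 4.7-fold higher number from compound 1 to compound 2 (0.67 log units; beyond the scatter) therefore rests on that limit (the limit of > 50000 nM in this assay, at which 1 of the 2 values shown sits). Compound 3 `COc1ccc2nc(Nc3ccnc(Nc4ccc(S(C)(=O)=O)cc4)n3)sc2c1` has not yet been measured in this assay; it differs from compound 2 by methoxy in place of methyl on an aromatic carbon. Among the compounds with values here, the single measured step bears on this only indirectly: it shows that the methyl weakened inhibition, but no step compares methyl with methoxy. For compound 3 the exchange is expected to leave the number near or somewhat below where compound 2 stands, a step of an at least 1.2-fold lower number from compound 2 to compound 3 (0.09 log units; that floor lies within the scatter). Compound 3 is thus estimated at 40000 nM, in a range from 10000 nM to 100000 nM.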

Compound 3, half-maximal inhibitory concentration: > 50000 nM
Compound 3 was reported as a limit (the forecaster's own chance of this, stated with the estimate: 55%); middle value at least 1.2-fold (0.09 log units) away from the limit.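

Compound 3 gives > 50000 nM in this assay, which is a limit of the assay and not a number. Methoxy in place of hydrogen on this aromatic carbon gives an at least 4.7-fold higher number from compound 1 to compound 3 (0.67 log units; beyond the scatter), so methyl is no longer the only group here that goes with weaker inhibition than hydrogen. The step from methyl to methoxy cannot be read, because both compounds end at the same limit: the limit of > 50000 nM in this assay, at which 2 of the 3 values shown sit.

As far as these compounds go, how far the true values of compound 2 and compound 3 lie beyond that limit remains open, so the two groups cannot be ranked. Also open, from the compounds shown here alone, is whether a fluorine, an amine or a carboxylic acid on this same aromatic carbon would stay near compound 1 or also reach the limit.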